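Varying the aromatic ring of the benzyloxy group

This account rests on a few compounds, and the source may have more. Where it says the series, first, only, none or still open, it means among the compounds named here.

Measured so far:
compound 1, `Cc1cc(C)cc(COc2ccc(-c3cc(CN4CCN(Cc5ccc(C(F)(F)F)cc5)CC4)no3)cc2)c1`: 1600 nM
compound 2, `FC(F)(F)c1ccc(CN2CCN(Cc3cc(-c4ccc(OCc5ccc(Cl)cc5)cc4)on3)CC2)cc1`: 6700 nM

Both numbers come from a functional assay on MCF7 cells (Homo sapiens) for antiproliferative activity, read by sulforhodamine B assay, with a stated time of 72 h; a higher number here means a weaker inhibitor, a lower number a stronger inhibitor. Going by the values given here, compound 2 holds the higher of the two numbers, with compound 1 as its only neighbour, and the single measured step, a 4.2-fold higher number from compound 1 to compound 2 (0.62 log units; beyond the scatter), is the exchange of 3,5-dimethylphenyl for 4-chlorophenyl on a saturated chain carbon bound to an oxygen on an aromatic ring.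

Compound 3, `N#Cc1cccc(COc2ccc(-c3cc(CN4CCN(Cc5ccc(C(F)(F)F)cc5)CC4)no3)cc2)c1`, is the next member. Among the compounds with values here, it differs from compound 2 by 3-cyanophenyl in place of 4-chlorophenyl on a saturated chain carbon bound to an oxygen on an aromatic ring, so the position touched is the same as in the one measured step, but the entering 3-cyanophenyl has no counterpart among the measured compounds. That step shows that a change at this position can move the number beyond the scatter, yet it gives no direction for a nitrile-bearing ring. The expectation for compound 3 is therefore a step of a 1.1-fold lower number from compound 2 to compound 3 (0.05 log units; within the scatter), which is no change beyond the scatter, with a wide range to cover either direction. Compound 3 is estimated at 6000 nM, between 2200 nM and 16000 nM.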

Compound 3, half-maximal inhibitory concentration: 800 nM
Beside the measured number, compound 3's estimate is 7.5-fold (0.88 log units) above it, outside the stated range (below it).
By their numbers in this assay, from the lowest: compounds 3 and 1 (each within the scatter of the next); then compound 2.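

In this assay, the aryl group on a saturated chain carbon bound to an oxygen on an aromatic ring proves able to move the number in both directions: an 8.4-fold lower number from compound 2 to compound 3 (0.92 log units; beyond the scatter) is a larger step than the one seen earlier and runs the opposite way. Among the three rings, 4-chlorophenyl alone stands apart, while a 2.0-fold lower number from compound 1 to compound 3 (0.30 log units; within the scatter) does not separate 3-cyanophenyl from 3,5-dimethylphenyl, so two rings with quite different substituents give numbers within the usual scatter of each other. Nothing available bears on the reason for the gap between the 4-chlorophenyl and 3-cyanophenyl compounds.

Compound 2 and compound 3 differ in both the kind of substituent and where it sits on the ring, so the compounds shown cannot say which of the two accounts for the step; 3-chlorophenyl and 4-cyanophenyl would separate them. Also open, going by these compounds, is how this position responds to an unsubstituted phenyl ring, or to a ring carrying an amine or a carboxylic acid.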